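A few compounds are considered here, and "the series" means these few. Any claim that something is new, unique, unknown or untested is made for them only; others in the source may bear on it.

In a functional assay on the whole organism (strain Sprague-Dawley) for inhibition, with Rattus norvegicus as the target, with a stated time of 10 min (on this read-out lower numbers stand for an effect already at smaller amounts and higher numbers for an effect only at larger amounts of compound), three compounds sharing one core have been measured. Compound 1 `O=C(O)c1cnc(-c2ccccc2)[nH]c1=O` gives 50 mg/kg, compound 2 `CCOc1ccccc1-c1ncc(C(=O)O)c(=O)[nH]1` gives 0.5 mg/kg, and compound 3 `CCOc1ccc([N+](=O)[O-])cc1-c1ncc(C(=O)O)c(=O)[nH]1` gives 25 mg/kg. Compound 2 therefore has the lowest number of the three, and both others lie beyond the scatter from it. Still unmeasured is compound 4 `CCOc1ccccc1-c1ncc(C(=O)O)c(=O)n1C`, which is compound 2 with a single change: methyl in place of hydrogen on an aromatic nitrogen, (methyl in place of hydrogen on an aromatic nitrogen). Among the compounds with values here, no measured step covers this change directly. The closest guides are two replacements on aromatic carbon: ethoxy in place of hydrogen, a 100-fold lower number from compound 1 to compound 2 (2.00 log units; beyond the scatter), and nitro in place of hydrogen, a 50-fold higher number from compound 2 to compound 3 (1.70 log units; beyond the scatter). Both steps are large, so a single replacement can clearly matter in this assay. Since compound 2 already sits at 0.5 mg/kg, the lowest number here, a move upward seems likelier than a further drop. The expected step, a large one toward a higher number, is a 30-fold higher number from compound 2 to compound 4 (1.48 log units; beyond the scatter). For compound 4 the estimated value is 15 mg/kg, with an expected range from 2 mg/kg to 100 mg/kg.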

Compound 4, dose for 50% inhibition: > 50 mg/kg
Compound 4 ended at the assay's limit; the forecaster's own chance of this, stated with the estimate: 25%; at least 3.3-fold (0.52 log units) between middle value and limit.
By their numbers in this assay, from the lowest: compound 2; then compounds 3 and 1 (each within the scatter of the next).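

The nitrogen of the shared core carries weight in this assay: methyl in place of hydrogen there gives an at least 100-fold higher number from compound 2 to compound 4 (2.00 log units; beyond the scatter), a large step that is beyond the scatter. The earlier steps shown here changed only aromatic carbons, so they said nothing about this hydrogen, and here a methyl of a single heavy atom is enough to undo the low number of compound 2. Compound 4 stands at > 50 mg/kg, which is a limit of the assay and not a number: the limit of > 50 mg/kg in this assay, at which 1 of the 4 values shown sits.

The compounds shown cannot separate the loss of the hydrogen from the arrival of the methyl, and they do not tell how far beyond the limit compound 4 really lies. Going by these compounds, whether an ethyl group, or a longer chain ending in an amine, on this same nitrogen would behave like methyl remains open.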